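The source may report more compounds than this note shows. Statements on the series, on what has been measured and on what is new or still open speak of the compounds shown alone.

Going by the values given here, compound 1 `N[C@H]1CC[C@H](Nc2c(C(=O)NCc3ccccn3)nc(Br)c3cccnc23)CC1` is one of only two compounds measured in a functional assay on MDA-MB-435 cells (Homo sapiens) for cytotoxicity, read by MTT assay, with a stated time of 72 h (on this read-out higher numbers stand for weaker inhibition and lower numbers for stronger inhibition), and in that setting compound 1 gives 4000 nM. The other measured compound, compound 2 `N[C@H]1CC[C@H](NC(=O)c2nc(Br)c3cccnc3c2NCc2ccc(F)cc2)CC1`, gives 6600 nM in this assay. Compound 1 holds the lowest of the two numbers, but the two values lie within the usual scatter of each other, so the gap between them carries no message about order or change.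

Compound 3 `C[C@H](NC(=O)c1nc(Br)c2cccnc2c1N[C@H]1CC[C@H](N)CC1)c1ccc(F)cc1` has not yet been measured. It differs from compound 1 in a single place, as follows: 1-(4-fluorophenyl)ethyl in place of (pyridin-2-yl)methyl on an amide-type nitrogen. Among the compounds with values here, no pair of measured compounds shows this same change, so there is no measured step to lean on, and the expectation below rests on caution rather than on an observed trend. The expected step is a 1.3-fold higher number from compound 1 to compound 3 (0.10 log units; within the scatter), which amounts to none beyond the scatter. On that basis compound 3 is estimated to give 5000 nM in this assay, with a plausible range from 1500 nM to 16000 nM.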

Compound 3, half-maximal inhibitory concentration: > 10000 nM
Compound 3: no number, only a limit; the forecaster's own chance of this, stated with the estimate: 10%; middle value at least 2.0-fold (0.30 log units) from the limit.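

In this assay compound 3 reads > 10000 nM, which is a limit of the assay and not a number. Going by these compounds alone, replacing (pyridin-2-yl)methyl with 1-(4-fluorophenyl)ethyl on the amide-type nitrogen gives an at least 2.5-fold higher number from compound 1 to compound 3 (0.39 log units; beyond the scatter), the first step in this small set that can be read at all, and it shows that inhibition in these cells does respond to what sits at this position, with the new group giving the weaker result. The step has a floor but no ceiling, so its true size stays unknown: the limit of > 10000 nM in this assay, at which 1 of the 3 values shown sits.

This single change does several things at once: it replaces a pyridine-type ring with a carbon-only ring, adds a fluorine, and brings in a defined stereocentre, and the compounds shown cannot say which of these matters. A (4-fluorophenyl)methyl group or a 1-(pyridin-2-yl)ethyl group on this nitrogen, or the mirror-image form of the 1-(4-fluorophenyl)ethyl group, would each separate one of these parts from the others, so their effect remains an open question.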